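The source may report more compounds than this note shows. Statements on the series, on what has been measured and on what is new or still open speak of the compounds shown alone.

Compound 1 `COCOc1cc(/C=C/C(=O)OCC(=O)Nc2ccc(Cl)cc2)ccc1OCc1ccccc1` is the starting point of the series. In a functional assay on HeLa cells (Homo sapiens) for cytotoxicity, read by MTT assay, with a stated time of 72 h (on this read-out higher numbers stand for weaker inhibition and lower numbers for stronger inhibition), compound 1 gives only a limit, > 200000 nM. Compound 3 `CCOc1ccc(COc2c(OC)cc(/C=C/C(=O)OCC(=O)Nc3ccc(Cl)cc3)cc2OC)cc1` likewise reaches only a limit in this assay, > 200000 nM. Compound 2 `O=C(COC(=O)/C=C/c1ccc(O)c(O)c1)Nc1ccc(Cl)cc1` gives 195000 nM in this assay, a number rather than a limit. Compound 1 therefore stands at the limit of detection, where two of the three values sit (the limit of > 200000 nM in this assay, at which 2 of the 3 values shown sit). The change to compound 4 `COCOc1cc(/C=C/C(=O)OCC(=O)NCc2ccco2)ccc1OCc1ccccc1` is (furan-2-yl)methyl in place of 4-chlorophenyl on an amide-type nitrogen. Within the data shown here, no measured pair in the set spans a change of this kind, so no step size can be read off; the expectation is a change of none beyond the scatter, and the expected step that the limit leaves unreadable from compound 1 to compound 4 is accordingly small. Compound 4 is expected to give 250000 nM, within a range of 120000 nM to 600000 nM, and most likely again only a limit.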

Compound 4, half-maximal inhibitory concentration: > 200000 nM
Compound 4: only a limit was reported; the forecaster's own chance of this, stated with the estimate: 70%; the middle value does not contradict the limit.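

Compound 4 gives only a limit in this assay, > 200000 nM. With compound 1 also at a limit, no step between compound 1 and compound 4 can be read: the limit of > 200000 nM in this assay, at which 3 of the 4 values shown sit.

The compounds shown leave open whether (furan-2-yl)methyl in place of 4-chlorophenyl on an amide-type nitrogen changes the read-out at all.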